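A few compounds are considered here, and "the series" means these few. Any claim that something is new, unique, unknown or untested is made for them only; others in the source may bear on it.

The series shares the core of compound 1 `COc1cc(N)c(Cl)cc1NC(=O)C1CCN(Cc2cccc(C)c2)CC1`, which in a functional assay on the whole organism for antagonist activity, with Mus musculus as the target (a lower number here means that less compound is needed, a higher number that more compound is needed for the effect), gives 2.4 mg/kg. Compound 2 `COc1cc(N)c(Cl)cc1NC(=O)C1CCN(C/C=C/c2ccccc2)CC1` carries a 2-phenylethenyl group where compound 1 has 3-methylphenyl. For compound 2 this assay returns no number but only a limit, > 10 mg/kg, so its position is known solely as a bound; this is the limit of > 10 mg/kg in this assay, at which 1 of the 2 values shown sits. Within the data shown here, the single measured step, an at least 4.1-fold higher number from compound 1 to compound 2 (0.61 log units; beyond the scatter), runs toward that limit. Compound 3 `COc1cc(N)c(Cl)cc1NC(=O)C1CCN(Cc2ccc(Cl)cc2)CC1` differs from compound 2 by 4-chlorophenyl in place of 2-phenylethenyl on a saturated chain carbon bound to an amine nitrogen in a ring, which takes away the double bond and restores a 4-chlorobenzyl of the same benzyl kind as in compound 1. Read in reverse, the expected change is an at least 3.3-fold lower number from compound 2 to compound 3 (0.52 log units; beyond the scatter), with the size left open by the limit of compound 2. The estimate for compound 3 in this assay is therefore 3 mg/kg, within 1 mg/kg to 10 mg/kg.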

Compound 3, dose for half-maximal effect: 1.2 mg/kg
Compound 3: middle estimate off by 2.5-fold (0.40 log units), on the high side; the measured number falls inside the stated range.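

Within the benzyl kind of group on a saturated chain carbon bound to an amine nitrogen in a ring, this assay shows an at least 8.3-fold lower number from compound 2 to compound 3 (0.92 log units; beyond the scatter), so the high number of compound 2 does not carry over to compound 3. Between the two benzyl groups, a 2.0-fold lower number from compound 1 to compound 3 (0.30 log units; within the scatter), so 4-chlorophenyl and 3-methylphenyl cannot be told apart at this position. Compound 2 gives only a limit, and the full size of its step stays open because of it: the limit of > 10 mg/kg in this assay, at which 1 of the 3 values shown sits.

Compound 2 differs from the other two in its double bond, its longer chain and its unsubstituted ring together, and a saturated 3-phenylpropyl group or a plain benzyl group would separate these. Also open, as far as these compounds go, is whether an amine or a carboxylic acid on the benzyl ring would match chlorine and methyl.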